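Moving the aminomethyl group on the phenyl ring

The compounds below may be only part of what the source reports. "The series", "measured", "known", "first", "only" and "open" are said of these compounds alone.

Among the compounds with values here, in a functional assay on CCRF-CEM cells (Homo sapiens) for inhibition (on this read-out lower numbers stand for stronger inhibition and higher numbers for weaker inhibition), compound 3 `Cn1cc(C#N)c2ccc(Nc3ncc(-c4ccccc4CN)o3)cc21` gives 1100 nM, the lowest number so far. Compound 1 `Cn1cc(C#N)c2ccc(Nc3ncc(-c4ccccc4)o3)cc21` gives 8000 nM. Compound 2 `Cc1cccc(-c2cnc(Nc3ccc4c(C#N)cn(C)c4c3)o2)c1` gives > 10000 nM, which is a limit of the assay.

Compound 4 `Cn1cc(C#N)c2ccc(Nc3ncc(-c4ccc(CN)cc4)o3)cc21` has the same atoms as compound 3, joined differently: 4-(aminomethyl)phenyl in place of 2-(aminomethyl)phenyl on an aromatic carbon. Here 4-(aminomethyl)phenyl replaces 2-(aminomethyl)phenyl.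

The closest evidence is a 7.3-fold lower number from compound 1 to compound 3 (0.86 log units; beyond the scatter), where adding aminomethyl brought a modest gain, and an at least 9.0-fold lower number from compound 2 to compound 3 (0.95 log units; beyond the scatter). Methyl alone gave an at least 1.2-fold higher number from compound 1 to compound 2 (0.09 log units; that floor lies within the scatter). Within the data shown here, no measured step moves the aminomethyl group, so the aminomethyl gain is expected to persist largely intact, with no change beyond the scatter. The expected step is a 1.4-fold higher number from compound 3 to compound 4 (0.13 log units; within the scatter). For compound 4 the estimated value is 1500 nM, within a range of 400 nM to 6000 nM.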

Compound 4, half-maximal inhibitory concentration: 2800 nM
For compound 4 the middle estimate is 1.9-fold (0.27 log units) below the measured one; the measured number falls inside the stated range.
By their numbers in this assay, from the lowest: compound 3; then compound 4; then compound 1. At a limit, above all of these: compound 2.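

In this assay the place of the aminomethyl group on the phenyl ring matters: going from 2-(aminomethyl)phenyl to 4-(aminomethyl)phenyl gives a 2.5-fold higher number from compound 3 to compound 4 (0.41 log units; beyond the scatter). The gain from aminomethyl survives the move but is smaller, with a 2.9-fold lower number from compound 1 to compound 4 (0.46 log units; beyond the scatter). Compound 2 stands at a limit, so an at least 3.5-fold lower number from compound 2 to compound 4 (0.55 log units; beyond the scatter) is only a floor: the limit of > 10000 nM in this assay, at which 1 of the 4 values shown sits.

From the compounds shown here alone, whether 3-(aminomethyl)phenyl would behave like either of these remains open. So does whether a longer chain such as 2-aminoethyl, or a carboxylic acid, on the phenyl ring would keep the gain.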